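Sulfonylurea variation on a bicyclic pyrazole series: compound 3 outlook

This account rests on a few compounds, and the source may have more. Where it says the series, first, only, none or still open, it means among the compounds named here.

Measured so far:
compound 1, `Cc1nc(C)c(S(=O)(=O)NC(=O)NC/C=C2\CCCc3cnn(Cc4ccc(Cl)cc4Cl)c32)s1`, 2 nM
compound 2, `CS(=O)(=O)c1ccc(-n2ncc3c2/C(=C/CNC(=O)NS(=O)(=O)c2cc(Cl)c(Cl)s2)CCC3)cc1`, 1 nM

Both measured compounds were run in an assay on isolated protein for displacement of a labelled ligand from prostaglandin E2 receptor EP3 subtype (Homo sapiens), read by scintillation counting, with a stated time of 2 h; a lower number here means a stronger inhibitor, a higher number a weaker inhibitor. Compound 1 gives 2 nM and compound 2 gives 1 nM; the two numbers lie within the scatter of each other, so neither compound can be called the stronger, and compound 1 simply stands as one of two closely matched, tightly binding sulfonylureas. For the measured compounds named here, no pair of measured compounds differs in a single place, so no step has been measured.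

Compound 3, `O=C(NC/C=C1\CCCc2cnn(Cc3ccc(Cl)cc3Cl)c21)NS(=O)(=O)c1ccc(Cl)cc1`, has not yet been measured. It differs from compound 1 as follows: 4-chlorophenyl in place of 2,4-dimethyl-1,3-thiazol-5-yl on a sulfonyl sulfur. The shared core, the urea and the sulfonyl linkage are kept; only the aromatic ring on the sulfonyl sulfur is exchanged.

Going by the values given here, with no measured step for guidance, the expectation rests on the two values alone. Both measured compounds carry a sulfonylurea and both bind tightly, so for compound 3 a step of a 2.0-fold higher number from compound 1 to compound 3 (0.30 log units; within the scatter) is expected, small and barely beyond the scatter if at all. Compound 3 is therefore estimated at 4 nM, with a range from 1 nM to 15 nM.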

Compound 3, inhibition constant: 4 nM
Beside the measured number, compound 3's estimate shows no gap at the digits printed; the range from low to high includes it.
By their numbers in this assay, from the lowest: compounds 2, 1 and 3 (each within the scatter of the next, the first and the last beyond it).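

In this assay, for the compounds shown here, the exchange on the sulfonyl sulfur gives a 2.0-fold higher number from compound 1 to compound 3 (0.30 log units; within the scatter) and is the first step read, so no difference in binding can be claimed for this change. In this pair, the aromatic ring on the sulfonyl sulfur can be either a five-membered ring with 2 hetero atoms and 2 hydrogen-bond acceptors or a six-membered ring of carbon only with 0 hydrogen-bond acceptors, and the value stays in the low nanomolar range; the acceptors of the 2,4-dimethyl-1,3-thiazol-5-yl group are therefore not required for tight binding on this core. No accompanying data bear on why the exchange is tolerated.

Still open, going by these compounds, is whether an aromatic ring on the sulfonyl sulfur is needed at all, a question that a methyl group or a longer alkyl chain at this place would answer. Equally open, on these data alone, is how far the 4-chlorophenyl ring tolerates change, for example a carboxylic acid or an amine in place of its chlorine.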